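The source may hold more compounds than are shown below. What is called first, only, known or untested is meant among the compounds shown, and "the series" means these compounds.

Measured compounds:
compound 1 `COc1cc2c(Oc3ccc(NC(=O)c4cn(-c5c(Cl)cccc5Cl)nn4)cc3F)ccnc2cc1OCCCN1CCCCC1` — in a functional assay on A549 cells (Homo sapiens) for cytotoxicity, read by MTT assay, with a stated time of 72 h (on this read-out higher numbers stand for weaker inhibition and lower numbers for stronger inhibition), compound 1 gives 150 nM
compound 2 `COc1cc2c(Oc3ccc(NC(=O)c4cn(-c5ccc(F)c(F)c5)nn4)cc3F)ccnc2cc1OCCCN1CCCCC1` — compound 2 gives 220 nM
compound 3 `COc1cc2c(Oc3ccc(NC(=O)c4cn(-c5c(Cl)cccc5Cl)nn4)cc3F)ccnc2cc1OCCCN1CCC(C)CC1` — compound 3 gives 320 nM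

Compound 4 `COc1cc2c(Oc3ccc(NC(=O)c4cn(-c5ccc(F)c(F)c5)nn4)cc3F)ccnc2cc1OCCCN1CCC(C)CC1` is not yet measured. Its relation to compound 3 is 3,4-difluorophenyl in place of 2,6-dichlorophenyl on an aromatic nitrogen. The same change has already been made once in this set, from compound 1 to compound 2, as 3,4-difluorophenyl in place of 2,6-dichlorophenyl on an aromatic nitrogen, where it gave a 1.5-fold higher number from compound 1 to compound 2 (0.17 log units; within the scatter). The place lines of the two changes read the same word for word, so the change is the same in both pairs. The two cores differ by methyl in place of hydrogen on a saturated ring carbon, a change that gave a 2.1-fold higher number from compound 1 to compound 3 (0.33 log units; beyond the scatter).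

The expectation for compound 4 rests on a single earlier instance of the change, so it is read as roughly repeating: the step from compound 3 to compound 4 is estimated as a 1.5-fold higher number from compound 3 to compound 4 (0.18 log units; within the scatter). Compound 4 is thus expected to give about 480 nM, most likely between 220 nM and 1000 nM.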

Compound 4, half-maximal inhibitory concentration: 1460 nM
Compound 4: the middle estimate sits 3.0-fold (0.48 log units) below what was measured; the whole stated range lies below it.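

In this assay, 3,4-difluorophenyl in place of 2,6-dichlorophenyl gives a 4.6-fold higher number from compound 3 to compound 4 (0.66 log units; beyond the scatter) on the methyl-bearing core, and this does not match the earlier step on the core of compound 1: the same change on two cores in this assay, a 1.5-fold higher number (0.17 log units; within the scatter) from compound 1 to compound 2 and a 4.6-fold higher number (0.66 log units; beyond the scatter) from compound 3 to compound 4, 3.1-fold (0.49 log units) apart, beyond the scatter of two such steps

Methyl in place of hydrogen on a saturated ring carbon likewise gives a 6.6-fold higher number from compound 2 to compound 4 (0.82 log units; beyond the scatter), which differs from its earlier step: the same change on two cores in this assay, a 2.1-fold higher number (0.33 log units; beyond the scatter) from compound 1 to compound 3 and a 6.6-fold higher number (0.82 log units; beyond the scatter) from compound 2 to compound 4, 3.1-fold (0.49 log units) apart, beyond the scatter of two such steps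

The size of each change therefore depends on the core in these four compounds, so neither step carries over directly here, but this single set of four shows neither a cause nor a rule for the wider series.

From the compounds shown here alone, it remains open whether the same dependence appears with unsubstituted phenyl on the aromatic nitrogen. The same question stands for ethyl in place of methyl on the saturated ring carbon.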